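The source may hold more compounds than are shown below. What is called first, only, known or untested is meant among the compounds shown, and "the series" means these compounds.

Measured in a functional assay on HT-1080 cells (Homo sapiens) for cytotoxicity, read by MTT assay, with a stated time of 72 h; a higher number here means a weaker inhibitor, a lower number a stronger inhibitor:
- compound 1 `COc1cccc(/C=C2\CCC/C(=C\c3ccccc3Cl)C2=O)c1OC` gives 11700 nM
- compound 2 `COc1cccc(/C=C2\CCC/C(=C\c3ccc(Cl)cc3)C2=O)c1OC` gives 11100 nM
- compound 3 `COc1cccc(/C=C2\CCC/C(=C\c3ccc(Br)cc3)C2=O)c1OC` gives 13700 nM

Compound 2 cannot be told apart from the other two compounds on these numbers: the steps are a 1.1-fold lower number from compound 1 to compound 2 (0.02 log units; within the scatter) and a 1.2-fold higher number from compound 2 to compound 3 (0.09 log units; within the scatter) and neither rises out of the noise between repeated measurements.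

Compound 4 `COc1ccccc1/C=C1\CCC/C(=C\c2cccc(OC)c2OC)C1=O` carries 2-methoxyphenyl in place of 4-chlorophenyl on a double-bonded chain carbon bound to a double-bonded ring carbon and otherwise matches compound 2. Going by the values given here, no measured compound has 2-methoxyphenyl at this place, so the evidence is indirect. The closest guide is the set of halogen swaps already shown, which also includes a 1.2-fold higher number from compound 1 to compound 3 (0.07 log units; within the scatter) and like the others stays small. The expectation is therefore no step beyond the scatter, with the estimated change being a 1.1-fold lower number from compound 2 to compound 4 (0.05 log units; within the scatter) in this assay and no firm direction. Compound 4 is expected at about 10000 nM with an estimated range from 3500 nM up to 25000 nM in this assay's terms.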

Compound 4, half-maximal inhibitory concentration: 14100 nM
Estimate against measurement, compound 4: 1.4-fold (0.15 log units) below, and the stated range covers the measured number.
By their numbers in this assay, from the lowest: compounds 2, 1, 3 and 4 (each within the scatter of the next).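

In this assay the steps of a 1.3-fold higher number from compound 2 to compound 4 (0.10 log units; within the scatter) and a 1.0-fold higher number from compound 3 to compound 4 (0.01 log units; within the scatter) and a 1.2-fold higher number from compound 1 to compound 4 (0.08 log units; within the scatter) all stay within the scatter, so 2-methoxyphenyl cannot be told apart from the halogen-bearing groups at this place. The earlier compounds shown here varied only the halogen and where it sat, whereas compound 4 brings in a different kind of group, with a hydrogen-bond acceptor that 4-chlorophenyl lacks, and the number still does not move out of the noise. No measurement here accounts for this flat result.

As far as these compounds go, it remains open whether any group at this place can move the number beyond the scatter, such as a phenyl ring carrying an amine or a carboxylic acid. A longer chain in place of methoxy is equally untested in the compounds shown.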